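The compounds below may be only part of what the source reports. "The series", "measured", "known", "first", "only" and "open" are said of these compounds alone.

Compound 1, `CC(=O)OC[C@H]1O[C@@H](n2cc(-c3cc(-c4ccc(C(C)(C)C)cc4)no3)c(=O)[nH]c2=O)C[C@@H]1OC(C)=O`, gives 112% in a functional assay on NCI-H23 cells (Homo sapiens) for cytotoxicity, read by sulforhodamine B assay, tested at 10 uM; a higher number here means more inhibition at the concentration tested (going by the name of the read-out), a lower number less inhibition. Compound 2, `CC(=O)OC[C@H]1O[C@@H](n2cc(-c3cc(-c4ccccc4)no3)c(=O)[nH]c2=O)C[C@@H]1OC(C)=O`, gives 91.4%. Compound 3, `CC(=O)OC[C@H]1O[C@@H](n2cc(-c3cn(Cc4ccccc4)nn3)c(=O)[nH]c2=O)C[C@@H]1OC(C)=O`, gives 98.2%.

Compound 1 and compound 2 share a core and differ only by tert-butyl in place of hydrogen on an aromatic carbon. That change made a step of a number 20.6 percentage points higher from compound 2 to compound 1 (beyond the scatter). The difference between the core of compound 3 and the core of compound 2 is not broken down here; compound 3 and compound 2 give values that lie within the scatter of each other.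

Compound 4, `CC(=O)OC[C@H]1O[C@@H](n2cc(-c3cn(Cc4ccc(C(C)(C)C)cc4)nn3)c(=O)[nH]c2=O)C[C@@H]1OC(C)=O`, is not yet measured. Going by the values given here, it differs from compound 3 by tert-butyl in place of hydrogen on an aromatic carbon, the same change as the one from compound 2 to compound 1, made at a place described in the same words. Because compound 2 to compound 1 showed a number 20.6 percentage points higher from compound 2 to compound 1 (beyond the scatter), a rise is expected for compound 4 as well, though compound 3 already gives 98.2%, so less room upward remains. The expected step is a number 9.8 percentage points higher from compound 3 to compound 4 (within the scatter). Compound 4 is thus estimated at 108%, with a likely range from 95% to 120%.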

Compound 4, a percentage reported as inhibition, at one concentration (the size of the read-out at that concentration, not a potency): 106%
The estimate for compound 4 lay 2 percentage points above the measured number; the range from low to high includes it.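

In this assay, tert-butyl in place of hydrogen on the benzyl group of compound 3 gives a number 7.8 percentage points higher from compound 3 to compound 4 (within the scatter). Set beside the same change on the other core, the two steps cannot be told apart: the same change on two cores in this assay, a number 20.6 percentage points higher (beyond the scatter) from compound 2 to compound 1 and a number 7.8 percentage points higher (within the scatter) from compound 3 to compound 4, 12.8 percentage points apart, within the scatter of two such steps. This agrees with the change carrying over from one core to the other, but it does not prove that it does: the new step alone cannot be separated from repeat-to-repeat variation, and two cores are too few to support a general rule for the series.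

The compounds shown have only hydrogen or tert-butyl at this position on the aromatic ring, so it remains open how a methyl group, a chlorine atom, an amine or a carboxylic acid would behave there. All of the readings also come from one cell line at one concentration, which leaves open how these compounds would compare at lower concentrations or in other cells.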